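Swapping tert-butyl for benzyl on the amine nitrogen

The source may hold more compounds than are shown below. What is called first, only, known or untested is meant among the compounds shown, and "the series" means these compounds.

Compound 1 `CCN(CCNC(=O)c1cc(Cl)c(N)cc1OC)Cc1ccccc1` gives 0.31 mg/kg
Compound 2 `CCN(CCNC(=O)c1cc(Cl)c(N)cc1OC)Cc1cccc(OC)c1` gives 1 mg/kg
Compound 3 `COc1cc(N)c(Cl)cc1C(=O)NCCN(Cc1ccccc1)C(C)(C)C` gives > 30 mg/kg

In a functional assay on the whole organism with Rattus norvegicus as the target (on this read-out higher numbers stand for an effect only at larger amounts of compound and lower numbers for an effect already at smaller amounts), compound 3 gives > 30 mg/kg as a limit of the assay, not as a number. Compound 4 `COc1cc(N)c(Cl)cc1C(=O)NCCN(Cc1ccccc1)Cc1ccccc1` is one change away from it, with benzyl in place of tert-butyl on an amine nitrogen as the counted difference: benzyl in place of tert-butyl on an amine nitrogen.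

Among the measured compounds shown here, two measured steps bear on this change. The closer one is an at least 96-fold higher number from compound 1 to compound 3 (1.98 log units; beyond the scatter) and it is large, coming from tert-butyl in place of ethyl on the same nitrogen, so this site clearly matters. The other is a 3.2-fold higher number from compound 1 to compound 2 (0.51 log units; beyond the scatter) and it is modest, coming from methoxy in place of hydrogen on an aromatic carbon. For the measured compounds named here, no measured step puts benzyl in place of ethyl, so the effect of a second benzyl on that nitrogen remains open.

Compound 4 no longer carries the tert-butyl of the large step, so a move toward a lower number is expected, though probably not all the way to compound 1 at 0.31 mg/kg on this scale. The expected change is an at least 6.0-fold lower number from compound 3 to compound 4 (0.77 log units; beyond the scatter) and it remains uncertain. For compound 4 the estimated value is 5 mg/kg with an expected range from 1 mg/kg to 25 mg/kg.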

Compound 4, dose for half-maximal effect: > 30 mg/kg
Compound 4 was reported as a limit; the forecaster's own chance of this, stated with the estimate: 30%; middle value at least 6.0-fold (0.77 log units) from the limit.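

In this assay, the loss of effect on this amine nitrogen does not belong to tert-butyl alone. Putting benzyl where the ethyl stood, so that the nitrogen carries two benzyl groups, gives an at least 96-fold higher number from compound 1 to compound 4 (1.98 log units; beyond the scatter), a loss as large as the one printed for tert-butyl, with an unbranched group that brings in an aromatic ring. The step from compound 3 to compound 4 cannot be read, because both ends of it are limits and not numbers: the limit of > 30 mg/kg in this assay, at which 2 of the 4 values shown sit.

Going by these compounds, how far compound 3 and compound 4 each lie past that limit stays unknown, so tert-butyl and benzyl cannot be ranked against each other on this nitrogen. The compounds shown also leave open where between ethyl and these two groups the effect disappears, for instance whether a propyl chain or an isopropyl group in place of ethyl would still act at doses close to those of compound 1.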